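The source may report more compounds than this note shows. Statements on the series, on what has been measured and on what is new or still open speak of the compounds shown alone.

Measured compounds:
compound 1 `O=C(Nc1ccccc1)Nc1nnc(Sc2ncnc3scc(-c4ccncc4)c23)s1` gives 19400 nM in a functional assay on HepG2 cells (Homo sapiens) for antiproliferative activity, read by MTT assay, with a stated time of 48 h; a higher number here means a weaker inhibitor, a lower number a stronger inhibitor
compound 2 `Cc1cccc(NC(=O)Nc2nnc(Sc3ncnc4scc(-c5ccncc5)c34)s2)c1` gives 20700 nM
compound 3 `O=C(Nc1ccc(Cl)c(C(F)(F)F)c1)Nc1nnc(Sc2ncnc3scc(-c4ccncc4)c23)s1` gives 45300 nM

Compound 3 has the highest number of the three; the nearest is compound 2, and the step from compound 1 to compound 3 is a 2.3-fold higher number from compound 1 to compound 3 (0.37 log units; beyond the scatter), while that from compound 2 to compound 3 is a 2.2-fold higher number from compound 2 to compound 3 (0.34 log units; beyond the scatter), both modest and beyond the scatter. Compound 4 `O=C(Nc1cccc(F)c1)Nc1nnc(Sc2ncnc3scc(-c4ccncc4)c23)s1` differs from compound 3 by 3-fluorophenyl in place of 4-chloro-3-(trifluoromethyl)phenyl on an amide-type nitrogen. Its ring substituent is closer in kind to those of compound 1 and compound 2 than to that of compound 3, and the steps of a 2.3-fold higher number from compound 1 to compound 3 (0.37 log units; beyond the scatter) and a 2.2-fold higher number from compound 2 to compound 3 (0.34 log units; beyond the scatter) were both modest. Compound 4 is therefore expected to move back toward those two, with an estimated 2.1-fold lower number from compound 3 to compound 4 (0.31 log units; beyond the scatter). The estimate for compound 4 is 22000 nM, with a range from 12000 nM to 45000 nM.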

Compound 4, half-maximal inhibitory concentration: 64100 nM
Estimate against measurement, compound 4: 2.9-fold (0.46 log units) below; the whole stated range lies below it.
By their numbers in this assay, from the lowest: compounds 1 and 2 (each within the scatter of the next); then compounds 3 and 4 (each within the scatter of the next).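

Replacing 4-chloro-3-(trifluoromethyl)phenyl on the amide-type nitrogen with 3-fluorophenyl gives a 1.4-fold higher number from compound 3 to compound 4 (0.15 log units; within the scatter), so these two groups cannot be told apart here. Among these compounds, a single fluoro is enough to separate the ring from those of the earlier compounds, with a 3.3-fold higher number from compound 1 to compound 4 (0.52 log units; beyond the scatter) for fluoro in place of hydrogen and a 3.1-fold higher number from compound 2 to compound 4 (0.49 log units; beyond the scatter) for fluoro in place of methyl, whereas methyl in place of hydrogen produced no step beyond the scatter. As far as these compounds go, whether an amine or a carboxylic acid on this phenyl ring would bring the number back toward that of compound 1 remains open. No evidence is available on what lies behind these steps.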